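From 2,4,6-trifluorophenyl to 1,3-thiazol-2-yl on an amide nitrogen

The source may hold more compounds than are shown below. What is called first, only, known or untested is meant among the compounds shown, and "the series" means these compounds.

Of the compounds shown here, two sharing one core have been measured so far in a functional assay on HCT-116 cells (Homo sapiens) for inhibition, read by colorimetric assay, with a stated time of 3 days; on this read-out lower numbers stand for stronger inhibition and higher numbers for weaker inhibition. Compound 1 `COc1ccc(NC(=O)CCCCCCNC(=O)C(O)(O)C(F)(F)F)cc1` gives 4520 nM, and compound 2 `O=C(CCCCCCNC(=O)C(O)(O)C(F)(F)F)Nc1c(F)cc(F)cc1F` gives 22200 nM, the higher of the two numbers and so the weaker inhibition. The next structure, compound 3 `O=C(CCCCCCNC(=O)C(O)(O)C(F)(F)F)Nc1nccs1`, keeps the core and changes one group: 1,3-thiazol-2-yl in place of 2,4,6-trifluorophenyl on an amide-type nitrogen. For the measured compounds named here, the only measured step at this place is a 4.9-fold higher number from compound 1 to compound 2 (0.69 log units; beyond the scatter), a modest one that put 2,4,6-trifluorophenyl in place of 4-methoxyphenyl on the amide-type nitrogen. Going by the values given here, no measured compound yet carries 1,3-thiazol-2-yl, so that single step gives only a rough scale. With compound 2 at the high end, a modest move toward a lower number in this assay is expected. The expected change is a 2.5-fold lower number from compound 2 to compound 3 (0.39 log units; beyond the scatter). For compound 3 the estimated value is 9000 nM, with an expected range from 3000 nM to 25000 nM.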

Compound 3, half-maximal inhibitory concentration: 10800 nM
The estimate for compound 3 lay 1.2-fold (0.08 log units) below the measured number; the measured number falls inside the stated range.
By their numbers in this assay, from the lowest: compound 1; then compound 3; then compound 2.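

In this assay, a five-membered aromatic ring with 2 hetero atoms on the amide-type nitrogen gives a 2.1-fold lower number from compound 2 to compound 3 (0.31 log units; beyond the scatter), so a ring of this kind is accepted here and the number does not rise compared with the 2,4,6-trifluorophenyl group. Set against the 4-methoxyphenyl group, the same 1,3-thiazol-2-yl group gives a 2.4-fold higher number from compound 1 to compound 3 (0.38 log units; beyond the scatter), which places it in the middle of the three and leaves 4-methoxyphenyl with the lowest number, all steps at this position being modest. Nothing measured here explains this order.

The compounds shown leave open how a plain phenyl ring, a pyridin-2-yl ring or a ring carrying a carboxylic acid would behave on this nitrogen. They also leave open what a longer chain in the shared core would do, as all three compounds keep the same chain.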